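The source may hold more compounds than are shown below. What is called first, only, known or untested is meant among the compounds shown, and "the series" means these compounds.

In a functional assay on the whole organism for inhibition, with Lemna aequinoctialis as the target, tested at 1000 ug/mL (on this read-out higher numbers stand for more inhibition of growth at the one concentration tested and lower numbers for less inhibition of growth), the three measured compounds gave these numbers:

compound 1 `CCCCCCNC(=S)N/N=C1\C(=O)Nc2ccc([N+](=O)[O-])cc21`: 60%
compound 2 `Cc1ccc(NC(=S)N/N=C2\C(=O)Nc3ccc([N+](=O)[O-])cc32)cc1`: 30%
compound 3 `O=C1Nc2ccc([N+](=O)[O-])cc2/C1=N/NC(=S)Nc1ccc(F)cc1`: 20%

Compound 3 is clearly separated only from compound 1, the step being a number 40 percentage points lower from compound 1 to compound 3 (beyond the scatter). Against compound 2 the step of a number 10 percentage points lower from compound 2 to compound 3 (within the scatter) lies within the scatter, so those two cannot be told apart. Compound 4 `N#Cc1cccc(NC(=S)N/N=C2\C(=O)Nc3ccc([N+](=O)[O-])cc32)c1` differs from compound 3 in one place: 3-cyanophenyl in place of 4-fluorophenyl on an amide-type nitrogen. The step that bears on it is a number 10 percentage points lower from compound 2 to compound 3 (within the scatter), a swap of one ring substituent for another that stayed within the scatter; the larger steps of a number 30 percentage points lower from compound 1 to compound 2 (beyond the scatter) and a number 40 percentage points lower from compound 1 to compound 3 (beyond the scatter) concern the hexyl-to-aryl change and do not apply here. No step beyond the scatter is therefore expected, a number 5 percentage points higher from compound 3 to compound 4 (within the scatter). Compound 4 is estimated at 25%, within 5% to 45%.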

Compound 4, percent growth inhibition at one concentration: 25%
For compound 4 middle estimate and measured number coincide at the digits printed; the range from low to high includes it.
By their numbers in this assay, from the lowest: compounds 3, 4 and 2 (each within the scatter of the next); then compound 1.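

In this assay the change to 3-cyanophenyl on the amide-type nitrogen gives a number 5 percentage points higher from compound 3 to compound 4 (within the scatter) and a number 5 percentage points lower from compound 2 to compound 4 (within the scatter) so this third aryl group, which carries a nitrile, cannot be told apart from 4-fluorophenyl or 4-methylphenyl. Against the hexyl chain it gives a number 35 percentage points lower from compound 1 to compound 4 (beyond the scatter) and so all three aryl compounds now lie clearly lower than compound 1. No measurement shown explains these results.

Still open, on these data alone, is whether a chain longer than hexyl would raise the number or lower it. Also open, as far as these compounds go, is whether an amine or a carboxylic acid on the aryl ring would separate from these three compounds.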